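Working notes: extending the sulfur substituent of compound 3

The source may report more compounds than this note shows. Statements on the series, on what has been measured and on what is new or still open speak of the compounds shown alone.

Measured so far in a functional assay on HepG2 cells (Homo sapiens) for inhibition, read by MTT assay, with a stated time of 48 h; a higher number here means a weaker inhibitor, a lower number a stronger inhibitor:
compound 1 `COc1ccc(-n2c(S)nnc2-c2cc(OC)c(OC)c(OC)c2)cc1` gives 57500 nM.
compound 2 `COc1ccc(-n2c(SCC(=O)Nc3ccc(Cl)cc3)nnc2-c2cc(OC)c(OC)c(OC)c2)cc1` gives only a limit, > 60000 nM.
compound 3 `COc1cc(-c2nnc(S)n2-c2ccc(N(C)C)cc2)cc(OC)c1OC` gives only a limit, > 60000 nM.

Compound 3 therefore stands at the limit of this assay, not at a number, and the limit of > 60000 nM in this assay, at which 2 of the 3 values shown sit, sets the frame for the series as a whole.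

Compound 4 `COc1cc(-c2nnc(SCC(=O)C3CC3)n2-c2ccc(N(C)C)cc2)cc(OC)c1OC` differs from compound 3 by (cyclopropylcarbonyl)methyl in place of hydrogen on a sulfur. For the measured compounds named here, the one measured step of the same kind, a group entering on the sulfur in place of hydrogen, is an at least 1.0-fold higher number from compound 1 to compound 2 (0.01 log units; that floor lies within the scatter), and it left compound 2 at the limit. On that basis no step beyond the scatter is expected here either, and compound 4 is expected to remain at or near the limit, the expected step being a step that the limit leaves unreadable from compound 3 to compound 4. For compound 4 the estimate is 70000 nM, with a range from 30000 nM to 150000 nM.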

Compound 4, half-maximal inhibitory concentration: > 60000 nM
Compound 4: a limit, no number (the forecaster's own chance of this, stated with the estimate: 65%); the middle value is on the limit's open side.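

Compound 3 and compound 4 both stand at a limit, not a number, in this assay, so no step between them can be read: the limit of > 60000 nM in this assay, at which 3 of the 4 values shown sit.

The compounds shown leave open whether any group on the sulfur of compound 3 brings a measurable value in this assay.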